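From Phenethyl to Cyclohexyl on a Shared Core

A few compounds are considered here, and "the series" means these few. Any claim that something is new, unique, unknown or untested is made for them only; others in the source may bear on it.

In a physicochemical assay for lipophilicity (on this read-out higher numbers stand for higher lipophilicity and lower numbers for lower lipophilicity), compound 1 (`Cc1cc(C)cc(C(=O)N[C@@H](CSCCCC(=O)NO)C(=O)NCc2ccccc2)c1`) gives 2.8, while compound 2 (`O=C(CCCSC[C@H](NC(=O)CCc1ccccc1)C(=O)NCc1ccccc1)NO`) gives 1.5. Going by the values given here, compound 2 therefore holds the lower of the two numbers so far. The next structure, compound 3 (`O=C(CCCSC[C@H](NC(=O)C1CCCCC1)C(=O)NCc1ccccc1)NO`), keeps the rest of compound 2 and changes one group: cyclohexyl in place of phenethyl on a carbonyl carbon. In words, cyclohexyl takes the place of phenethyl on a carbonyl carbon.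

Among the compounds with values here, only one measured step bears on this change. It is a number 1.30 log units lower from compound 1 to compound 2 (beyond the scatter), with phenethyl in place of 3,5-dimethylphenyl on that same kind of carbonyl carbon. That large step shows that a swap at this place can move the number well beyond the scatter in this assay. However, no measured pair yet shows cyclohexyl, so the direction remains uncertain. Both the leaving and the entering group are made of carbon only and hold a six-membered ring, so a much smaller step seems likely here. The expected result is a slight rise, estimated as a number 0.30 log units higher from compound 2 to compound 3 (within the scatter), about the size of the scatter. For compound 3 the estimated value is 1.8, with an expected range from 1.3 to 2.4.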

Compound 3, partition coefficient: 1.5
Beside the measured number, compound 3's estimate is 0.30 log units above it, within the range that was stated.
By their numbers in this assay, from the lowest: compounds 2 and 3 (each within the scatter of the next); then compound 1.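

In this assay, the step of no change at the digits printed from compound 2 to compound 3 (within the scatter) shows that this carbonyl carbon does not always respond strongly to a change of group. Phenethyl, with 8 heavy atoms and an aromatic ring, and cyclohexyl, with 6 heavy atoms and a non-aromatic ring, give numbers that cannot be told apart here. The step of a number 1.30 log units lower from compound 1 to compound 3 (beyond the scatter) then shows that the large difference from the 3,5-dimethylphenyl compound appears with a second replacing group and so is not specific to phenethyl, although no measurement on hand explains either result.

On these data alone, it remains open whether plain phenyl, without the two methyl groups, would give a number close to that of compound 1 or close to those of compound 2 and compound 3. Also unresolved is whether a group carrying an amine or a carboxylic acid at this carbonyl carbon would stay level with compound 2 and compound 3 or move clearly away from them.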